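This account rests on a few compounds, and the source may have more. Where it says the series, first, only, none or still open, it means among the compounds named here.

Measured so far:
compound 1 `Cc1ccc2occ(C(=O)Nc3ccccc3)c(=O)c2c1` — 21.4 nM
compound 2 `Cc1ccc(NC(=O)c2coc3ccc(C)cc3c2=O)cc1` — 152 nM

In an assay on cells for inhibition of Amine oxidase [flavin-containing] B (Homo sapiens), read by fluorescence and Amplex Red, using microsomes, with a stated time of 15 min (a lower number here means a stronger inhibitor, a higher number a weaker inhibitor), compound 1 gives 21.4 nM, and compound 2 gives 152 nM. Within the data shown here, compound 2 thus stands with the higher of the two numbers, its only neighbour being compound 1, the step of a 7.1-fold higher number from compound 1 to compound 2 (0.85 log units; beyond the scatter) lying beyond the scatter. Compound 3 `Cc1ccc2occ(C(=O)Nc3ccc(Cl)cc3)c(=O)c2c1` differs from compound 2 by chloro in place of methyl on an aromatic carbon. Among the measured compounds shown here, no measured step covers this exchange; the single step at hand, a 7.1-fold higher number from compound 1 to compound 2 (0.85 log units; beyond the scatter), concerns a different group entering the same phenyl ring and so says only that a change at that ring can move this assay by a modest amount. Compound 3 is therefore expected to land near compound 2, with a step of a 2.5-fold lower number from compound 2 to compound 3 (0.40 log units; beyond the scatter) that is not foreseen to exceed the scatter with confidence in either direction. The estimate for compound 3 in this assay is 60 nM, with a range from 10 nM to 350 nM.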

Compound 3, half-maximal inhibitory concentration: 45.4 nM
Compound 3: middle estimate off by 1.3-fold (0.12 log units), on the high side; low and high end bracket the measured number.
By their numbers in this assay, from the lowest: compound 1; then compound 3; then compound 2.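

In this assay, the place para to a large group on this ring does not treat its two one-atom groups alike: chloro in place of methyl gives a 3.3-fold lower number from compound 2 to compound 3 (0.52 log units; beyond the scatter). Chloro still does not match hydrogen at this place, with a 2.1-fold higher number from compound 1 to compound 3 (0.33 log units; beyond the scatter), so among these three compounds both groups give a higher number than hydrogen, though chloro gives the smaller rise. Nothing at hand accounts for the gap between chloro and methyl.

The compounds shown leave open whether another group at this place, such as fluoro, methoxy or an amine, would match or go below the number of compound 1. They also leave open whether the order of hydrogen, chloro and methyl would hold if the methyl on the shared core were replaced by another group.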